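The source may hold more compounds than are shown below. What is called first, only, known or untested is meant among the compounds shown, and "the series" means these compounds.

Working notes on the series, step from compound 1 to compound 4.

Compound 1 `Clc1ccc(/C=N/Nc2nc3ccccc3nc2Cc2ccccc2)cc1` gives 84000 nM in an assay on isolated protein for inhibition of Amine oxidase [flavin-containing] B (Homo sapiens), read by spectrophotometry; a higher number here means a weaker inhibitor, a lower number a stronger inhibitor. Among the three measured numbers it stands lowest, yet compound 2 `Clc1ccccc1/C=N/Nc1nc2ccccc2nc1Cc1ccccc1` with 87000 nM sits within the scatter of it, as the step of a 1.0-fold higher number from compound 1 to compound 2 (0.02 log units; within the scatter) shows, so no order between these two is claimed. Compound 3 `C/C(=N\Nc1nc2ccccc2nc1Cc1ccccc1)c1cccs1` gives 850000 nM and lies beyond the scatter of both: a 10-fold higher number from compound 1 to compound 3 (1.01 log units; beyond the scatter) and a 9.8-fold higher number from compound 2 to compound 3 (0.99 log units; beyond the scatter).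

Compound 4 `Cc1ccsc1/C=N/Nc1nc2ccccc2nc1Cc1ccccc1` is not yet measured. Its change from compound 1 is 3-methylthiophen-2-yl in place of 4-chlorophenyl on a carbon with a double bond to nitrogen. Of the measured steps, the exchange from compound 1 to compound 3 bears most closely on it, since there too a five-membered aromatic ring with 1 hetero atom replaced the six-membered aromatic ring of carbon only, and the number rose by a 10-fold higher number from compound 1 to compound 3 (1.01 log units; beyond the scatter). That step, however, also brought a change at the carbon with a double bond to nitrogen, which compound 4 does not share, so the present step need not be as large. The ring-position change from compound 1 to compound 2 was within the scatter and gives no lead on direction.

Compound 4 is therefore expected to give a higher number than compound 1, with a step of about a 3.0-fold higher number from compound 1 to compound 4 (0.47 log units; beyond the scatter), and the estimate for compound 4 is 250000 nM with a range from 90000 nM to 700000 nM.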

Compound 4, half-maximal inhibitory concentration: 860000 nM
Compound 4: the middle estimate sits 3.4-fold (0.54 log units) below what was measured, and the stated range ends below it.
By their numbers in this assay, from the lowest: compounds 1 and 2 (each within the scatter of the next); then compounds 3 and 4 (each within the scatter of the next).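

In this assay, 3-methylthiophen-2-yl in place of 4-chlorophenyl on a carbon with a double bond to nitrogen raises the number by a large step on its own, a 10-fold higher number from compound 1 to compound 4 (1.01 log units; beyond the scatter), and the exchange from 2-chlorophenyl gives a matching rise, a 9.9-fold higher number from compound 2 to compound 4 (0.99 log units; beyond the scatter). The further change at that carbon in compound 3 is therefore not required for a rise of this size: compound 4 lacks it, yet a 1.0-fold higher number from compound 3 to compound 4 (0.01 log units; within the scatter), so no order between these two is claimed, and among the compounds shown, both five-membered rings go with the higher numbers and both chlorophenyl groups with the lower numbers. No measurement is at hand that accounts for this rise.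

On these data alone, whether the rise follows the entry of the five-membered aromatic ring or the departure of chlorine stays open, and an unsubstituted phenyl on the same carbon would separate the two. Also open, as far as these compounds go, are the part played by the methyl on the thiophene, which an unsubstituted thiophen-2-yl would test, and whether an amine or a carboxylic acid on the six-membered ring would shift the number in either direction.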